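Compound 2 and its methyl analogue, compound 4

The compounds below may be only part of what the source reports. "The series", "measured", "known", "first", "only" and "open" are said of these compounds alone.

In a functional assay on SK-OV-3 cells (Homo sapiens) for antiproliferative activity, read by MTT assay (a higher number here means a weaker inhibitor, a lower number a stronger inhibitor), compound 2 `N#Cc1c(F)c(F)c(C(C(=O)c2ccccc2)=C2NCCN2)c(C#N)c1F` gives 30.3 ug/mL and stands second highest of three numbers. It is level with compound 1 `N#Cc1c(F)c(Cl)c(C(C(=O)c2ccccc2)=C2NCCN2)c(C#N)c1F` at 32.6 ug/mL and well above compound 3 `N#Cc1c(F)c(C#N)c(C(C(=O)c2ccccc2)=C2NCCN2)c(F)c1Nc1ccccc1` at 0.2 ug/mL on this scale. Compound 4 `Cc1ccc(C(=O)C(=C2NCCN2)c2c(F)c(F)c(C#N)c(F)c2C#N)cc1` differs from compound 2 on the benzoyl, which becomes (4-methylphenyl)carbonyl, with methyl in place of hydrogen on an aromatic carbon as the whole change.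

Neither measured step touches the benzoyl. The change of fluoro in place of chloro gives a 1.1-fold lower number from compound 1 to compound 2 (0.03 log units; within the scatter) and stays within the scatter, while anilino in place of fluoro gives a 150-fold lower number from compound 2 to compound 3 (2.18 log units; beyond the scatter) and is large. For the measured compounds named here, both therefore bear only indirectly, and the data offer no direct precedent for this methyl. No step beyond the scatter is expected in this assay here. The expected step is a 1.0-fold lower number from compound 2 to compound 4 (0.00 log units; within the scatter) on this estimate. For compound 4 the estimated value is 30 ug/mL with an expected range of 13 ug/mL to 65 ug/mL in this read-out.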

Compound 4, half-maximal inhibitory concentration: 2 ug/mL
Beside the measured number, compound 4's estimate is 15-fold (1.18 log units) above it; the whole stated range lies above it.
By their numbers in this assay, from the lowest: compound 3; then compound 4; then compounds 2 and 1 (each within the scatter of the next).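

In this assay, the benzoyl end of the molecule turns out to matter: methyl in place of hydrogen on an aromatic carbon, para to a large group, gives a 15-fold lower number from compound 2 to compound 4 (1.18 log units; beyond the scatter) and so moves the number beyond the scatter. The earlier steps shown here lay elsewhere on the shared core, so they showed nothing about this position, and this single added carbon shows that the position responds to a very small change. No evidence on hand accounts for the size of this step.

On these data alone, what remains open is whether this response is particular to methyl, or whether ethyl, methoxy, chloro or an amine on the same carbon would give a similar number. The compounds shown also leave open whether the 4-methylphenyl change and the anilino change of compound 3 would add up in one molecule.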